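Three Limits and One Open Swap

A few compounds are considered here, and "the series" means these few. Any claim that something is new, unique, unknown or untested is made for them only; others in the source may bear on it.

Compound 1 (`C=C[C@@](C)(/C=C/c1ccc(OS(=O)(=O)c2ccc(C)cc2)cc1)CCC=C(C)C`): > 49000 nM
Compound 2 (`C=C[C@@](C)(/C=C/c1ccc(O)cc1)CC/C=C(\C)C=O`): > 49000 nM
Compound 3 (`C=C[C@@](C)(/C=C/c1ccc(O)c(/C=C/C(=O)OCc2ccccc2)c1)CCC=C(C)C`): > 49000 nM

In a functional assay on Jurkat cells (Homo sapiens) for cytotoxicity, with a stated time of 72 h (on this read-out higher numbers stand for an effect only at larger amounts of compound and lower numbers for an effect already at smaller amounts), compound 3 gives only a limit (> 49000 nM), not a number. It shares that position with the other two compounds (the limit of > 49000 nM in this assay, at which 3 of the 3 values shown sit). Compound 4 (`C=C[C@@](C)(/C=C/c1ccc(O)c(/C=C/C=C/c2ccccc2)c1)CCC=C(C)C`) carries 2-phenylethenyl in place of benzyloxycarbonyl on a double-bonded chain carbon bound to a double-bonded chain carbon. Going by the values given here, no measured pair shows what this swap does. Among the compounds with values here, the only guide is that shared limit, so no change beyond the usual scatter is expected in this assay, and the estimated step is small (an at least 1.2-fold lower number from compound 3 to compound 4 (0.08 log units; that floor lies within the scatter)). For compound 4 the expected value is (40000 nM), with an estimated range from 15000 nM to 49000 nM.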

Compound 4, half-maximal effective concentration: > 49000 nM
Compound 4 was reported as a limit; the forecaster's own chance of this, stated with the estimate: 65%; middle value at least 1.2-fold (0.08 log units) away from the limit.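

Compound 3 and compound 4 are both reported only as limits, so the change to 2-phenylethenyl in place of benzyloxycarbonyl gives no step that can be read: the limit of > 49000 nM in this assay, at which 4 of the 4 values shown sit.

The compounds shown leave open what actual number any of them would give in this assay, and so what this swap does.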